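Swapping the Side Group of Compound 2

This account rests on a few compounds, and the source may have more. Where it says the series, first, only, none or still open, it means among the compounds named here.

Of the compounds shown here, two have so far been tested in a functional assay on PC-3 cells (Homo sapiens) for inhibition, read by CellTiter-Glo, with a stated time of 72 h; a higher number here means that more compound is tolerated, a lower number that less compound is tolerated. Compound 1 `CC1=C(CC(=O)N2CCN(CCCN(C)C)CC2)c2cc(F)ccc2/C1=C\c1ccc([S+](C)[O-])cc1` gave only a limit, > 50000 nM, not a number. Within the data shown here, compound 2 `CC1=C(CC(=O)NCCN2CCCC2)c2cc(F)ccc2/C1=C\c1nc2ccccc2s1` holds the only actual number, 4940 nM. Compound 3 `CC1=C(CC(=O)N2CCN(CCCN(C)C)CC2)c2cc(F)ccc2/C1=C\c1nc2ccccc2s1` keeps the rest of compound 2 but has 4-(3-(dimethylamino)propyl)piperazin-1-yl in place of (2-(pyrrolidin-1-yl)ethyl)amino on a carbonyl carbon. Among the measured compounds shown here, compound 1 carries the same entering group, yet it also differs from compound 3 elsewhere, so no measured pair isolates this swap. The expectation therefore stays anchored on compound 2 at 4940 nM, with no shift beyond the scatter and only a slight lean towards more compound being tolerated. The step expected in this assay is a 1.2-fold higher number from compound 2 to compound 3 (0.08 log units; within the scatter). For compound 3 the estimate is 6000 nM, with an expected range from 2000 nM to 25000 nM.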

Compound 3, half-maximal cytotoxic concentration: 4210 nM
Beside the measured number, compound 3's estimate is 1.4-fold (0.15 log units) above it; low and high end bracket the measured number.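

In this assay, the swap on the carbonyl carbon gives a 1.2-fold lower number from compound 2 to compound 3 (0.07 log units; within the scatter), so the two side groups cannot be told apart here, even though the entering group has more heavy atoms and no hydrogen-bond donor. With that side group held fixed, the group on the double-bonded chain carbon makes a far larger difference, with an at least 11-fold lower number from compound 1 to compound 3 (1.07 log units; beyond the scatter). The value of compound 1 is a limit and not a number: the limit of > 50000 nM in this assay, at which 1 of the 3 values shown sits.

From the compounds shown here alone, it remains open whether a side group without an amine, such as a carboxylic acid on the carbonyl carbon, would give a number close to that of compound 3. Also open, going by these compounds, is how a plain phenyl or a pyridine ring on the double-bonded chain carbon would compare with the two groups seen there.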